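This account rests on a few compounds, and the source may have more. Where it says the series, first, only, none or still open, it means among the compounds named here.

Measured so far in an assay on isolated protein for inhibition of DNA topoisomerase 1 (Homo sapiens), with a stated time of 30 min, tested at 100 uM; on this read-out lower numbers stand for a weaker effect and higher numbers for a stronger effect at the one concentration tested:
compound 1 `Oc1cccc(-c2cc(-c3ccc(Cl)cc3)nc(-c3ccco3)c2)c1` gives 27.1%
compound 2 `Oc1cccc(-c2cc(-c3ccc(Cl)cc3)nc(-c3cccnc3)c2)c1` gives 2.8%

Among the compounds with values here, compound 2 stands lowest of the two numbers; the only measured step, a number 24.3 percentage points lower from compound 1 to compound 2 (beyond the scatter), puts compound 1 above it beyond the scatter.

Compound 3 `Oc1cccc(-c2cc(-c3ccccc3)nc(-c3ccc(Cl)cc3)c2)c1` is not yet measured. Against compound 2 the change is phenyl in place of pyridin-3-yl on an aromatic carbon. Within the data shown here, no measured pair shows this exchange; the step of a number 24.3 percentage points lower from compound 1 to compound 2 (beyond the scatter) shows only that exchanging the group at this place moves this assay modestly. Among the measured compounds shown here, with no closer precedent, compound 3 is expected to rise modestly over compound 2, a number 12.2 percentage points higher from compound 2 to compound 3 (beyond the scatter), estimated at 15% with a range of 0% to 40%.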

Compound 3, a percentage reported as inhibition, at one concentration (the size of the read-out at that concentration, not a potency): 7.1%
Estimate against measurement, compound 3: 7.9 percentage points above; low and high end bracket the measured number.
By their numbers in this assay, from the lowest: compounds 2 and 3 (each within the scatter of the next); then compound 1.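

In this assay, exchanging pyridin-3-yl for phenyl at this place gives no readable change: a number 4.3 percentage points higher from compound 2 to compound 3 (within the scatter). The ring nitrogen of pyridin-3-yl therefore carries no visible weight here, while furan-2-yl stays apart from both six-membered aromatic rings, with a number 20 percentage points lower from compound 1 to compound 3 (beyond the scatter). Nothing at hand explains this difference.

As far as these compounds go, it remains open whether thiophen-2-yl would hold the level of furan-2-yl. Also open, from the compounds shown here alone, is whether an amine or a carboxylic acid on the phenyl at this place would move the number at all.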